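Exchanging 4-ethylbenzyl for 1-(4-chlorophenyl)ethyl

The compounds below may be only part of what the source reports. "The series", "measured", "known", "first", "only" and "open" are said of these compounds alone.

In a functional assay on the whole organism for inhibition, with Rattus norvegicus as the target (on this read-out higher numbers stand for an effect only at larger amounts of compound and lower numbers for an effect already at smaller amounts), compound 1 (`CCc1ccc(CC(C)(Oc2ccc(C(C)C)cc2)C(=O)NS(=O)(=O)C(F)(F)F)cc1`) reads > 10 mg/kg as its value, which is a limit and not a number. Compound 2 (`CC(C)c1ccc(OC(C)(C(=O)O)C(C)c2ccc(Cl)cc2)cc1`) gives > 10 mg/kg; 2.5 mg/kg (2 entries) as its entries. Compound 3 (`CC(C)c1ccc(OC(C)(C(=O)NS(=O)(=O)C(F)(F)F)C(C)c2ccc(Cl)cc2)cc1`) differs from compound 1 by a single exchange (1-(4-chlorophenyl)ethyl in place of 4-ethylbenzyl on a saturated chain carbon bound to a carbonyl carbon, an oxygen on an aromatic ring and a saturated chain carbon): 1-(4-chlorophenyl)ethyl in place of 4-ethylbenzyl on a saturated chain carbon bound to a carbonyl carbon, an oxygen on an aromatic ring and a saturated chain carbon. Among the compounds with values here, no measured step isolates this exchange. The only support for expecting a gain is compound 2 (the several entries of compound 2 in this assay, > 10 mg/kg; 2.5 mg/kg (2 entries)), which carries the same entering group. The expected step of an at least 2.0-fold lower number from compound 1 to compound 3 (0.30 log units; that floor lies within the scatter) points toward smaller doses in this assay and is a rough estimate. For compound 3 the estimated dose is 5 mg/kg (expected range 1.5 mg/kg to 20 mg/kg) and another limit reading remains possible.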

Compound 3, dose for half-maximal effect: > 10 mg/kg
Compound 3 was reported as a limit; the forecaster's own chance of this, stated with the estimate: 40%; middle value at least 2.0-fold (0.30 log units) from the limit.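

In this assay compound 1 and compound 3 are both reported only as limits, so no step can be read between them. The compounds shown leave open whether 1-(4-chlorophenyl)ethyl in place of 4-ethylbenzyl changes the dose for half-maximal effect at all.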